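The source may hold more compounds than are shown below. What is called first, only, known or untested is meant among the compounds shown, and "the series" means these compounds.

Of the compounds shown here, two have been measured so far in a functional assay on HCC827 cells (Homo sapiens) for inhibition, read by MTT assay, with a stated time of 48 h, tested at 10 uM; on this read-out higher numbers stand for more inhibition at the one concentration tested (going by the name of the read-out) and lower numbers for less inhibition. Compound 1 `COc1cc(Nc2cc(NC(=O)Nc3c(Cl)cccc3Cl)ncn2)cc(OC)c1` gives 73.7%. Compound 2 `COc1cc(NC(=O)Nc2cc(Nc3ccc(C)c(F)c3)ncn2)cc(OC)c1` gives 72% in this assay; this is the lower of the two numbers, but the gap to compound 1 lies within the scatter, so the two compounds cannot be separated on this read-out. Compound 3 `COc1cc(NC(=O)Nc2cc(Nc3cc(I)ccc3OC)ncn2)cc(OC)c1` has not yet been measured. It differs from compound 2 at one place: 5-iodo-2-methoxyphenyl in place of 3-fluoro-4-methylphenyl on a nitrogen on an aromatic ring. For the measured compounds named here, no pair of measured compounds differs at a single place, so no measured step shows what such a change does. Because compound 1 gives 73.7% and compound 2 gives 72% despite their different structures, only a modest change is expected for compound 3. The step of a number 4 percentage points lower from compound 2 to compound 3 (within the scatter) is expected to stay within the scatter. Compound 3 is therefore estimated to give 68% in this assay, with a range from 45% to 85%.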

Compound 3, a percentage reported as inhibition, at one concentration (the size of the read-out at that concentration, not a potency): 71%
For compound 3 the middle estimate is 3 percentage points below the measured one; the measured number falls inside the stated range.
By their numbers in this assay, from the lowest: compounds 3, 2 and 1 (each within the scatter of the next).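

Putting 5-iodo-2-methoxyphenyl in place of 3-fluoro-4-methylphenyl on a nitrogen on an aromatic ring gives a step of a number 1 percentage points lower from compound 2 to compound 3 (within the scatter) in this assay, so this read-out cannot tell the two groups apart. For the compounds shown here, this is the first view of a change at a single place: the position holds either ring, even though the entering group carries iodine and a methoxy group and has a hydrogen-bond acceptor that the leaving group lacks. No measurement at hand explains why the two groups read alike.

Since several features change at once, the compounds shown cannot say what the iodine or the methoxy group does alone. Going by these compounds, it also stays open whether a ring bearing a carboxylic acid or a morpholine at this position would read the same.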